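The source may hold more compounds than are shown below. What is called first, only, known or untested is meant among the compounds shown, and "the series" means these compounds.

Measured so far in an assay on isolated protein for inhibition of Maltase-glucoamylase (Homo sapiens), tested at 100 uM; a lower number here means less inhibition, a higher number more inhibition at the concentration tested (going by the name of the read-out):
compound 1 `C=C1CC[C@@H]2[C@](C)(CO)[C@H](O)CC[C@@]2(C)/C1=C/C=C1\C=COC1=O` gives "not active" (no number reported)
compound 2 `C=C1CC[C@@H]2[C@](C)(CO)[C@H](O)CC[C@@]2(C)[C@@H]1/C=C/C1=C/C(=C/C)OC1=O` gives 15.1%
compound 3 `C=C1CC[C@@H]2[C@](C)(CO)[C@H](O)CC[C@@]2(C)[C@@H]1/C=C/C1=CC(=C(C)C)OC1=O` gives 17.1%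

Compound 2 holds the lower of the two reported numbers, but its nearest neighbour, compound 3, sits only a number 2 percentage points higher from compound 2 to compound 3 (within the scatter) away, a step within the scatter, so the two cannot be ranked. Compound 4 `C=C1CC[C@@H]2[C@](C)(CO)[C@H](O)CC[C@@]2(C)[C@@H]1/C=C/C1=C/C(=C/C=C(/C)CCC=C(C)C)OC1=O` differs from compound 2 by 2,6-dimethylhepta-1,5-dien-1-yl in place of methyl on a double-bonded chain carbon bound to a double-bonded ring carbon. Among the compounds with values here, the only measured step, a number 2 percentage points higher from compound 2 to compound 3 (within the scatter), exchanged one five-membered ring group for a slightly larger one and left the read-out within the scatter; nothing measured speaks to a long chain entering in place of methyl. With that small step as the sole reference, no movement beyond the scatter is expected, and compound 4 is estimated at 18% (range 5% to 35%), an expected step of a number 2.9 percentage points higher from compound 2 to compound 4 (within the scatter) in this assay.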

Compound 4, a percentage reported as inhibition, at one concentration (the size of the read-out at that concentration, not a potency): "not active" (no number reported)
Compound 4 has no reported number here; the estimate stays without a comparison.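

Compound 4 has no number to set against compound 2, so no step between them can be read, and no measured evidence accounts for this result. The compounds shown leave open whether the 2,6-dimethylhepta-1,5-dien-1-yl chain in place of methyl changes inhibition at all.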